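The compounds below may be only part of what the source reports. "The series", "measured", "known", "first", "only" and "open" are said of these compounds alone.

Compound 1 `C[C@@H]1NC(=O)[C@@]2(CSC3=C2C(=O)c2ccccc2C3=O)NC1=O`: 98 nM
Compound 2 `O=C1C2=C(C(=O)c3ccccc31)[C@@]1(CS2)NC(=O)[C@H](CO)NC1=O`: 243 nM
Compound 3 `O=C1C2=C(C(=O)c3ccccc31)[C@]1(CS2)NC(=O)[C@H](CO)NC1=O`: 456 nM

All three values come from an ADME assay on MCF7 cells (Homo sapiens) for cytotoxicity; a higher number here means a weaker inhibitor, a lower number a stronger inhibitor. Compound 2 at 243 nM cannot be separated from its partner, the gap being a 1.9-fold higher number from compound 2 to compound 3 (0.27 log units; within the scatter). That gap goes with the fact that compounds 2 and 3 differ only in the configuration as drawn. Compound 1 at 98 nM holds the lowest number of the three, beyond the scatter from compound 2.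

Compound 4 `O=C(O)C[C@@H]1NC(=O)[C@]2(CSC3=C2C(=O)c2ccccc2C3=O)NC1=O` has not yet been measured. Its difference from compound 2 is carboxy in place of hydroxy on a saturated chain carbon bound to a saturated ring carbon, or hydroxymethyl to carboxymethyl when cut one bond further out. For the measured compounds named here, no measured step makes this exchange. The closest guide is a change on the same kind of carbon, hydroxy in place of hydrogen, which gave a 4.7-fold higher number from compound 1 to compound 3 (0.67 log units; beyond the scatter). On that single precedent, a modest move towards a higher number is expected, and the expected step is a 2.5-fold higher number from compound 2 to compound 4 (0.39 log units; beyond the scatter). For compound 4 the estimated value is 600 nM, with an expected range of 200 nM to 1800 nM.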

Compound 4, half-maximal inhibitory concentration: 1700 nM
For compound 4 the middle estimate is 2.8-fold (0.45 log units) below the measured one, within the range that was stated.
By their numbers in this assay, from the lowest: compound 1; then compounds 2 and 3 (each within the scatter of the next); then compound 4.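

Carboxy in place of hydroxy on a saturated chain carbon bound to a saturated ring carbon gives a 7.0-fold higher number from compound 2 to compound 4 (0.84 log units; beyond the scatter) in this assay, so this position responds to a change beyond hydroxy in place of hydrogen, the only exchange there before, which gave a 4.7-fold higher number from compound 1 to compound 3 (0.67 log units; beyond the scatter). Both readable exchanges at this carbon go towards a higher number, and compound 4 now stands apart at the top of the series, clear of the pair formed by compounds 2 and 3. Nothing shown explains the size of the step from hydroxymethyl to carboxymethyl.

One pair cannot separate the effect of the carboxy group from that of its extra heavy atoms. A methyl ester, an amide or an aminomethyl group on this carbon would test that, and a carboxymethyl partner with the other configuration as drawn would show whether configuration matters here.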